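Swapping the Benzyl Group for a Furylmethyl Group

The compounds below may be only part of what the source reports. "The series", "measured", "known", "first", "only" and "open" are said of these compounds alone.

Measured in an ADME assay on HepG2 cells (Homo sapiens) for cytotoxicity, read by luminescence, CellTiter-Glo and ATP content, with a stated time of 72 h; on this read-out higher numbers stand for an effect only at larger amounts of compound and lower numbers for an effect already at smaller amounts:
Compound 1, `COc1cccc(CNCCCNc2ccnc3cc(Oc4ccc(F)cc4)ccc23)c1O`: 11000 nM
Compound 2, `CCC(CC)c1ccc2c(NCCCNCc3cccc(OC)c3O)ccnc2c1`: 410 nM

Compound 2 stands at the lower of the two numbers. For the measured compounds named here, the only measured step, a 27-fold lower number from compound 1 to compound 2 (1.43 log units; beyond the scatter), concerns the group on the core and is large. Compound 3, `CCC(CC)c1ccc2c(NCCCNCc3ccco3)ccnc2c1`, differs from compound 2 in another place: furan-2-yl in place of 2-hydroxy-3-methoxyphenyl on a saturated chain carbon bound to an amine nitrogen. Going by the values given here, no measured step touches this part of the molecule, so the data give no direction for it. Compound 3 is therefore expected to stay close to compound 2, with a step of a 1.5-fold higher number from compound 2 to compound 3 (0.17 log units; within the scatter). The estimate for compound 3 is 600 nM, within 150 nM to 2500 nM.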

Compound 3, half-maximal effective concentration: 6760 nM
For compound 3 the middle estimate is 11-fold (1.05 log units) below the measured one; measured number above the stated range.
By their numbers in this assay, from the lowest: compound 2; then compounds 3 and 1 (each within the scatter of the next).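

In this assay, replacing 2-hydroxy-3-methoxybenzyl with (furan-2-yl)methyl gives a 16-fold higher number from compound 2 to compound 3 (1.22 log units; beyond the scatter) and so moves the effect to larger amounts of compound. The group on the saturated chain carbon bound to an amine nitrogen therefore affects this read-out, which the earlier pair, differing only on the core, could not show. Nothing measured here explains the shift.

Still open, going by these compounds, is which part of the change matters: the hydroxy group, the methoxy group or the ring itself. A plain benzyl or 2-hydroxybenzyl group at this place would help separate these.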